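Sulfonyl to sulfonamide exchange on a carbamate series

A few compounds are considered here, and "the series" means these few. Any claim that something is new, unique, unknown or untested is made for them only; others in the source may bear on it.

Measured compounds:
compound 1 `CCOc1ccc(NC(=S)N2CCC(C(O)(c3ccccc3)c3ccccc3)CC2)cc1C#N` 323 nM
compound 2 `CN(C)S(=O)(=O)c1ccc(NC(=S)N2CCC(C(O)(c3ccccc3)c3ccccn3)CC2)cc1` 98 nM
compound 3 `O=C(Oc1ccc(S(=O)(=O)N2CCCC2)cc1)N1CCC(C(O)(c2ccccc2)c2ccccc2)CC1` 49 nM

Of the compounds shown here, three have been tested in a functional assay for antagonist activity at Neuropeptide Y receptor type 2 (Homo sapiens); a lower number here means a stronger inhibitor, a higher number a weaker inhibitor. Compound 3 gives 49 nM, the lowest of the three numbers. Its nearest neighbour is compound 2, which gives 98 nM in this assay, and that gap lies within the scatter of repeated measurements, so no order can be read between these two. Compound 1 gives 323 nM in this assay, and that gap to compound 3 lies beyond the scatter, so compound 3 stands clearly lower than compound 1.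

Compound 4 `CS(=O)(=O)Nc1ccc(OC(=O)N2CCC(C(O)(c3ccccc3)c3ccccc3)CC2)cc1` has not yet been measured in this assay. It differs from compound 3 in one place: methanesulfonamido in place of (pyrrolidin-1-yl)sulfonyl on an aromatic carbon. Among the compounds with values here, no step between two measured compounds corresponds to this exchange, so nothing in the data shows its size or direction. The account therefore expects a small step, if any, from compound 3 to compound 4 in this assay, most likely not beyond the scatter, with a slight lean toward a higher number. The expected value for compound 4 is 80 nM, with a range from 25 nM to 260 nM, which corresponds to an expected step of a 1.6-fold higher number from compound 3 to compound 4 (0.21 log units; within the scatter).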

Compound 4, half-maximal inhibitory concentration: 394 nM
Compound 4: the middle estimate sits 4.9-fold (0.69 log units) below what was measured; the measured number lies above the stated range.
By their numbers in this assay, from the lowest: compounds 3 and 2 (each within the scatter of the next); then compounds 1 and 4 (each within the scatter of the next).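

In this assay, within the data shown here, the change from (pyrrolidin-1-yl)sulfonyl to methanesulfonamido on the aromatic carbon para to a large group gives an 8.0-fold higher number from compound 3 to compound 4 (0.91 log units; beyond the scatter), the first step in this set that isolates a single place, and it lies beyond the scatter. This position is therefore not indifferent to what it carries, even though both groups hold a sulfonyl unit and neither has a net charge. The entering group is smaller, has no ring and brings a hydrogen-bond donor that the leaving group lacks, but nothing measured here bears on which of these differences matters, or on why the number rises.

Among these compounds, the single step changes all of these features at once, so it remains open whether an open-chain dimethylaminosulfonyl, a morpholin-4-ylsulfonyl or a methanesulfonamido with a methyl group on its nitrogen would stay close to compound 3 or move toward compound 4. As far as these compounds go, it also remains open whether the same exchange would give a step of similar size on the thiourea compounds, since compound 1 and compound 2 each differ from these carbamates in more than one place.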